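The source may hold more compounds than are shown below. What is called first, only, known or untested is meant among the compounds shown, and "the series" means these compounds.

In a functional assay, read by spectrophotometry, tested at 100 uM (on this read-out higher numbers stand for weaker inhibition and lower numbers for stronger inhibition), compound 1 (`O=C(/C=C/c1ccco1)c1cccc(NC(=O)c2cc(-c3ccncc3)n[nH]2)c1`) gives 41800 nM and compound 2 (`COc1ccccc1/C=C/C(=O)c1cccc(NC(=O)c2cc(-c3ccncc3)n[nH]2)c1`) gives 41700 nM. These two numbers lie within the scatter of each other, so compound 2 stands level with compound 1. Compound 3 (`CC(C)c1ccc(/C=C/C(=O)c2cccc(NC(=O)c3cc(-c4ccncc4)n[nH]3)c2)cc1`) has not yet been measured. It differs from compound 2 at a single place: 4-isopropylphenyl in place of 2-methoxyphenyl on a double-bonded chain carbon bound to a double-bonded chain carbon. In words, 4-isopropylphenyl stands in place of 2-methoxyphenyl on a double-bonded chain carbon bound to a double-bonded chain carbon. Among the compounds with values here, only one measured step bears on this change, a 1.0-fold lower number from compound 1 to compound 2 (0.00 log units; within the scatter), which swaps the group at that same place and stays within the scatter. On this single step, no change beyond the scatter is expected in this assay, in either direction, although one step is thin evidence. The expected step is a 1.0-fold lower number from compound 2 to compound 3 (0.01 log units; within the scatter). For compound 3 the estimated value is 41000 nM, with an expected range from 17000 nM to 95000 nM.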

Compound 3, half-maximal inhibitory concentration: 52300 nM
Beside the measured number, compound 3's estimate is 1.3-fold (0.11 log units) below it; low and high end bracket the measured number.
By their numbers in this assay, from the lowest: compounds 2, 1 and 3 (each within the scatter of the next).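

In this assay, 4-isopropylphenyl in place of 2-methoxyphenyl gives a 1.3-fold higher number from compound 2 to compound 3 (0.10 log units; within the scatter), and 4-isopropylphenyl in place of furan-2-yl gives a 1.3-fold higher number from compound 1 to compound 3 (0.10 log units; within the scatter); both steps lie within the scatter. Three different ring groups at this place, on a double-bonded chain carbon bound to a double-bonded chain carbon, therefore stand level, and this now holds for an exchange that takes away the hydrogen-bond acceptor of 2-methoxyphenyl and enters a group with none. No measurement is available to explain this flat result.

As far as these compounds go, all three compounds carry a ring group at this place, so it remains open whether an amine or a carboxylic acid there would move the number beyond the scatter. The compounds shown also share one core, and they say nothing about changes made to it.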